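The source may report more compounds than this note shows. Statements on the series, on what has been measured and on what is new or still open speak of the compounds shown alone.

Compound 1 `NC(=S)Nc1cccc(OCCCCCN2CCN(c3ccc(Cl)c(Cl)c3)C2=S)c1`: in an ADME assay on Huh-7 cells (Homo sapiens) for cytotoxicity (a higher number here means that more compound is tolerated, a lower number that less compound is tolerated), compound 1 reaches only a limit of the assay, > 50000 nM.
Compound 2 `NC(=S)Nc1cccc(OCCCCCNC(=S)Nc2cc(Cl)cc(Cl)c2)c1`: in this assay compound 2 gives 18000 nM.
Compound 3 `NC(=S)Nc1cccc(OCCCCCCCCNC(=S)Nc2cc(Cl)cc(Cl)c2)c1`: in this assay compound 3 gives 12000 nM.

Of the two numbers, compound 3 has the lower one, yet it and compound 2 lie within the usual scatter of each other, so no order between them can be claimed. Compound 4 `NC(=S)Nc1cccc(OCCCCCCCCNC(=S)Nc2ccccc2Br)c1` is not yet measured. It differs from compound 3 in one place: 2-bromophenyl in place of 3,5-dichlorophenyl on an amide-type nitrogen. Among the compounds with values here, no measured step in this assay shows what such a change does, and the two numbers known so far sit close together. The step from compound 3 to compound 4 is therefore expected to be small, a 1.3-fold higher number from compound 3 to compound 4 (0.10 log units; within the scatter), none beyond the scatter in either direction. Compound 4 is estimated at 15000 nM, with a range from 6000 nM to 50000 nM.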

Compound 4, half-maximal cytotoxic concentration: 36000 nM
The estimate for compound 4 lay 2.4-fold (0.38 log units) below the measured number, and the stated range covers the measured number.
By their numbers in this assay, from the lowest: compounds 3, 2 and 4 (each within the scatter of the next, the first and the last beyond it). At a limit, above all of these: compound 1.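

In this assay, the group on the amide-type nitrogen proves able to shift the number: 2-bromophenyl in place of 3,5-dichlorophenyl gives a 3.0-fold higher number from compound 3 to compound 4 (0.48 log units; beyond the scatter), a modest step, yet beyond the usual scatter. It is the first step here between compounds that differ in one place, so this position is now shown to respond. Nothing known about these compounds explains this step.

On these data alone, whether the bromine or the loss of the two chlorines drives the step stays open, and plain phenyl or 2-chlorophenyl would help separate them. Also open, as far as these compounds go, is whether the same change would act alike on the shorter chain of compound 2.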